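Fluorine Added to the Central Ring of Compound 3

The compounds below may be only part of what the source reports. "The series", "measured", "known", "first", "only" and "open" are said of these compounds alone.

Compound 1, `Cc1cc(C)cc(NC(=O)Nc2ccc(Nc3ncnc4c3OCCN4)cc2)c1`, gives 1070 nM in an assay on isolated protein for inhibition of proto-oncogene tyrosine-protein kinase receptor Ret (Homo sapiens), read by 33P incorporation, with stated times of 15 min and 40 min; on this read-out higher numbers stand for weaker inhibition and lower numbers for stronger inhibition.
Compound 2, `O=C(Nc1ccc(Nc2ncnc3c2OCCN3)cc1)Nc1cc(Cl)cc(Cl)c1`, gives 865 nM.
Compound 3, `CC(C)(C)c1cc(NC(=O)Nc2ccc(Nc3ncnc4c3OCCN4)cc2)no1`, gives 10 nM.

Compound 3 stands lowest of the three; its nearest neighbour is compound 2, and the steps to it and to compound 1 are both large: an 87-fold lower number from compound 2 to compound 3 (1.94 log units; beyond the scatter) and a 110-fold lower number from compound 1 to compound 3 (2.03 log units; beyond the scatter). The remaining step, a 1.2-fold lower number from compound 1 to compound 2 (0.09 log units; within the scatter), is within the scatter. Compound 4, `CC(C)(C)c1cc(NC(=O)Nc2ccc(Nc3ncnc4c3OCCN4)cc2F)no1`, differs from compound 3 by fluoro in place of hydrogen on an aromatic carbon. Among the measured compounds shown here, none of the measured steps touches this place; all three alter the group on the amide-type nitrogen, so they give no direct guidance. Compound 4 is therefore expected to show no step beyond the scatter, no change at the digits printed from compound 3 to compound 4 (within the scatter). The estimate for compound 4 is 10 nM, with a range from 3 nM to 35 nM.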

Compound 4, half-maximal inhibitory concentration: 10 nM
Compound 4: middle estimate and measured number agree at the digits printed, and the stated range covers the measured number.
By their numbers in this assay, from the lowest: compounds 3 and 4 (each within the scatter of the next); then compounds 2 and 1 (each within the scatter of the next).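

In this assay, fluoro in place of hydrogen on an aromatic carbon, ortho to a large group, gives no change at the digits printed from compound 3 to compound 4 (within the scatter). Among the compounds shown here, the earlier steps all altered the group on the amide-type nitrogen, so this is the first reading at this place, and it shows that the ring carbon accepts fluoro without a step beyond the scatter. Nothing at hand explains this result.

As far as these compounds go, whether chloro, methoxy or an amine on this carbon would leave the number unchanged stays open, as does the effect of fluoro on the ring's other carbons.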